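Methyl on the aromatic nitrogen of compound 2

The source may hold more compounds than are shown below. What is called first, only, known or untested is meant among the compounds shown, and "the series" means these compounds.

Working from the shared core, the three measured compounds differ only in the group on an oxygen on an aromatic ring. In a functional assay on HeLa cells (Homo sapiens) for antiproliferative activity, read by MTT assay, with a stated time of 48 h (on this read-out lower numbers stand for stronger inhibition and higher numbers for weaker inhibition), compound 1 `COc1cc(-c2nnc3c(OC(C)C)cc(-c4ccc5[nH]ccc5c4)cn23)cc(OC)c1OC` gives 261 nM and compound 2 `COc1cc(-c2nnc3c(OCC(F)(F)F)cc(-c4ccc5[nH]ccc5c4)cn23)cc(OC)c1OC` gives 348 nM, with a 1.3-fold higher number from compound 1 to compound 2 (0.12 log units; within the scatter) separating the pair. Compound 3 `COc1cc(-c2nnc3c(OC4CCC4)cc(-c4ccc5[nH]ccc5c4)cn23)cc(OC)c1OC` gives 142 nM. The step of a 1.8-fold lower number from compound 1 to compound 3 (0.26 log units; within the scatter) also stays small, while a 2.5-fold lower number from compound 2 to compound 3 (0.39 log units; beyond the scatter) is the only one that clears the scatter. Compound 2 therefore holds the highest of the three numbers, though it is not set apart from compound 1.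

Compound 4 `COc1cc(-c2nnc3c(OCC(F)(F)F)cc(-c4ccc5c(ccn5C)c4)cn23)cc(OC)c1OC` keeps the 2,2,2-trifluoroethyl group of compound 2 and changes a different place: methyl in place of hydrogen on an aromatic nitrogen. In words, this is methyl in place of hydrogen on an aromatic nitrogen. Among the measured compounds shown here, no measured step touches that nitrogen, so the data give neither a direct size nor a firm direction for this change. For the measured compounds named here, they show only that the steps seen so far at the oxygen are small to modest, the largest being a 2.5-fold lower number from compound 2 to compound 3 (0.39 log units; beyond the scatter). The expected result is a 1.4-fold lower number from compound 2 to compound 4 (0.14 log units; within the scatter), which would be no change beyond the scatter in this assay. For compound 4 the estimated value is 250 nM, with an expected range from 80 nM to 700 nM.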

Compound 4, half-maximal inhibitory concentration: 199 nM
Compound 4: middle estimate off by 1.3-fold (0.10 log units), on the high side, within the range that was stated.
By their numbers in this assay, from the lowest: compounds 3, 4, 1 and 2 (each within the scatter of the next, the first and the last beyond it).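

Every earlier compound carried the hydrogen on the aromatic nitrogen of the five-membered aromatic ring, so the series had given no reading at this place until now. In this assay, the change from 1H-indol-5-yl to 1-methyl-1H-indol-5-yl, with 2,2,2-trifluoroethyl held on the oxygen, gives a 1.7-fold lower number from compound 2 to compound 4 (0.24 log units; within the scatter) and so stays inside the scatter: with that oxygen group in place, methyl can stand on this nitrogen without a step that can be told from repeat measurement, and the hydrogen is not needed to keep the number in this range. Among the compounds shown here, nothing at hand bears on the reason for this result, and the single pair gives only its size.

Open, on these data alone, is whether the same replacement holds with isopropyl or cyclobutyl on the oxygen, since the reading at the nitrogen rests on the 2,2,2-trifluoroethyl compounds alone. Also open, as far as these compounds go, is how much more this nitrogen tolerates: an ethyl group, a longer chain, a chain ending in an amine or a carboxylic acid, or an acetyl group in place of methyl could show whether the flat step persists beyond a single carbon.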